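Swapping the Amide Aryl Group for a Methylsulfonylphenyl

The source may report more compounds than this note shows. Statements on the series, on what has been measured and on what is new or still open speak of the compounds shown alone.

Compound 1 `O=C(Nc1ccc(Cl)c(-c2nnc3c(Cl)cccn23)c1)c1ccc(C(F)(F)F)cc1F`: 70800 nM
Compound 2 `O=C(Nc1ccc(Cl)c(-c2nnc3c(Cl)cccn23)c1)c1cccc(Cl)c1`: 30200 nM
Compound 3 `Cc1cc(Cl)ccc1C(=O)Nc1ccc(Cl)c(-c2nnc3c(Cl)cccn23)c1`: > 100000 nM

All three share one core and differ only in the aryl group on the amide carbonyl. In a functional assay on T47D cells (Homo sapiens) for antiproliferative activity, read by MTT assay, with a stated time of 72 h (a higher number here means a weaker inhibitor, a lower number a stronger inhibitor), compound 1 gives 70800 nM and compound 2 gives 30200 nM. Compound 3 is known only as a limit, > 100000 nM, not as a number (the limit of > 100000 nM in this assay, at which 1 of the 3 values shown sits). For the measured compounds named here, the single measured step, an at least 3.3-fold higher number from compound 2 to compound 3 (0.51 log units; beyond the scatter), moved the value to that limit. Compound 4 `CS(=O)(=O)c1cccc(C(=O)Nc2ccc(Cl)c(-c3nnc4c(Cl)cccn34)c2)c1` now carries 3-(methylsulfonyl)phenyl in place of 4-chloro-2-methylphenyl on a carbonyl carbon. It returns to a ring bearing a single group, as in compound 2, whose 30200 nM is the nearest guide, though all three show weak inhibition. Compound 4 is therefore expected at 50000 nM, within 15000 nM to 150000 nM, an estimated step of an at least 2.0-fold lower number from compound 3 to compound 4 (0.30 log units; that floor lies within the scatter).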

Compound 4, half-maximal inhibitory concentration: > 100000 nM
Compound 4: a limit, no number (the forecaster's own chance of this, stated with the estimate: 40%); at least 2.0-fold (0.30 log units) between middle value and limit.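

Methylsulfonyl in place of the chloro of compound 2 gives an at least 3.3-fold higher number from compound 2 to compound 4 (0.51 log units; beyond the scatter), so a ring bearing a single group can also lose the weak activity seen in compound 2. Compound 4 is known only as a limit, > 100000 nM, and compound 3 is also a limit, so the step between them cannot be read. Compounds now sit at that ceiling: the limit of > 100000 nM in this assay, at which 2 of the 4 values shown sit.

As far as these compounds go, whether an amine or a carboxylic acid in place of that chloro would give a measurable value, stronger or weaker than compound 2, stays open.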